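Notes on the step from compound 1 to compound 4

The source may report more compounds than this note shows. Statements on the series, on what has been measured and on what is new or still open speak of the compounds shown alone.

Compound 1 `COc1cc(-c2cc(/C=C/C(=O)c3ccc(Cl)c(Cl)c3)[nH]n2)cc(OC)c1OC` gives 99% in a functional assay on A549 cells (Homo sapiens) for cytotoxicity, read by sulforhodamine B assay, with a stated time of 48 h, tested at 0.1 uM (a lower number here means a stronger effect, a higher number a weaker effect of the compound at the concentration tested), the highest of the three numbers at hand, though compound 3 `COc1ccc(-c2cc(/C=C/C(=O)c3ccc(N)cc3)[nH]n2)cc1` with 98% and compound 2 `COc1ccc(-c2cc(/C=C/C(=O)c3ccc(N)cc3)[nH]n2)cc1OC` with 93% both sit within the scatter of it. Among the measured compounds shown here, the only single-point step available, a number 5 percentage points higher from compound 2 to compound 3 (within the scatter), is within the scatter as well. Compound 4 `COc1ccc(C(=O)/C=C/c2cc(-c3cc(OC)c(OC)c(OC)c3)n[nH]2)cc1OC` differs from compound 1 by 3,4-dimethoxyphenyl in place of 3,4-dichlorophenyl on a carbonyl carbon. For the measured compounds named here, no measured step touches an exchange on the carbonyl carbon, so nothing among the measured pairs argues for a shift in either direction, and all numbers so far lie close together near full activity. Compound 4 is therefore expected at 97%, range 88% to 104%. The expected step of a number 2 percentage points lower from compound 1 to compound 4 (within the scatter) is none beyond the scatter.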

Compound 4, a percentage reported as activity, at one concentration (the size of the read-out at that concentration, not a potency): 98%
For compound 4 the middle estimate is 1 percentage points below the measured one; the range from low to high includes it.
By their numbers in this assay, from the lowest: compounds 2, 3, 4 and 1 (each within the scatter of the next).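

In this assay the reading is a number 1 percentage points lower from compound 1 to compound 4 (within the scatter) with 3,4-dimethoxyphenyl in place of 3,4-dichlorophenyl on a carbonyl carbon. Among the compounds shown here, this is the first step read at this position, and the two aryl groups cannot be told apart here at the single concentration tested. Nothing at hand explains this result.

From the compounds shown here alone, whether any group at this position can separate from the scatter stays open, for instance a piperidine or a 4-carboxyphenyl on the carbonyl carbon. Also open, going by these compounds, is whether these two aryl groups would differ at a higher concentration.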